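The compounds below may be only part of what the source reports. "The series", "measured", "known", "first", "only" and "open" are said of these compounds alone.

Measured so far:
compound 1 `Cc1c(OCCCCOCOc2ccc(C(=O)O)cc2)ccc(C(=O)CC2CCCC2)c1O` — 46.9%
compound 2 `CCC(=O)c1ccc(OCCCCOc2cc(C(=O)O)ccc2OC)c(C)c1O` — 62.5%

Two compounds have been run in an assay on HEK293 cells for positive allosteric modulation of metabotropic glutamate receptor 3 (Rattus norvegicus), read by thallium flux, with a stated time of 2.5 min; a lower number here means a smaller maximal response, a higher number a larger maximal response. Compound 1 gives 46.9%. Compound 2 gives 62.5%, the higher of the two numbers; the gap to compound 1 lies beyond the usual scatter. Among the measured compounds shown here, the two structures differ in more than one place, so nothing is recorded as a single step between them, and the pair shows only that compound 2 reaches the larger maximal response.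

Compound 3 `COc1ccc(C(=O)O)cc1OCCCCOc1ccc(C(=O)CC2CCCC2)c(O)c1C` has not been measured in this assay. It differs from compound 2 in one place: cyclopentyl in place of methyl on a saturated chain carbon bound to a carbonyl carbon. Compound 1 also carries cyclopentyl at that position, but with a different linker, so its value cannot be tied to this change alone.

For the measured compounds named here, with no single-point step recorded, a modest move is expected from compound 2 to compound 3 in this assay, downward, near the edge of the scatter; the expected step is a number 10.5 percentage points lower from compound 2 to compound 3 (beyond the scatter). Compound 3 is therefore estimated at 52%, with a range from 38% to 66%.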

Compound 3, largest response reached (reported as percent of maximum), in percent of the reference or control that the assay uses: 67.6%
Estimate against measurement, compound 3: 15.6 percentage points below; measured number above the stated range.
By their numbers in this assay, from the lowest: compound 1; then compounds 2 and 3 (each within the scatter of the next).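

In this assay, cyclopentyl in place of methyl on a saturated chain carbon bound to a carbonyl carbon gives a number 5.1 percentage points higher from compound 2 to compound 3 (within the scatter), so the two compounds cannot be told apart by maximal response, even though the entering group brings five carbons and a ring. With cyclopentyl held at that place, 5-carboxy-2-methoxyphenyl in place of (4-carboxyphenoxy)methyl on an oxygen on a saturated carbon gives a number 20.7 percentage points higher from compound 1 to compound 3 (beyond the scatter), so among the steps that can be read, the one beyond the scatter lies at that oxygen-borne group and not at the chain carbon. No data at hand give a reason for either step.

Methyl and cyclopentyl are the only two groups compared at the chain carbon, so it remains open whether a cyclohexyl ring, a longer chain or a group carrying an amine would fit the same pattern. The step at the oxygen-borne group also exchanges the whole group at once, leaving open whether the methoxy, the place of the carboxylic acid or the linking atoms account for it.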